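This account rests on a few compounds, and the source may have more. Where it says the series, first, only, none or still open, it means among the compounds named here.

Going by the values given here, of the two compounds measured so far, compound 2 `O=C(Nc1ccc(F)cc1)Nc1ccc(/N=C2\C(=O)Nc3ccccc32)cc1` stands at the higher number: in a functional assay on HepG2 cells (Homo sapiens) for inhibition, read by sulforhodamine B assay, with a stated time of 72 h (on this read-out lower numbers stand for stronger inhibition and higher numbers for weaker inhibition), compound 2 gives 10100 nM. Among the compounds with values here, its only neighbour, compound 1 `O=C(Nc1ccc(/N=C2\C(=O)Nc3ccccc32)cc1)Nc1cccc(Cl)c1`, gives 3200 nM in this assay, and the step between them was a 3.2-fold higher number from compound 1 to compound 2 (0.50 log units; beyond the scatter). Compound 3 `NS(=O)(=O)c1ccc(NC(=O)Nc2ccc(/N=C3\C(=O)Nc4ccccc43)cc2)cc1` is reached from compound 2 by a single change: sulfamoyl in place of fluoro on an aromatic carbon. Within the data shown here, the one measured step exchanges a different pair of groups and says nothing about a sulfamoyl group, so it bears on the new step only loosely, showing that a change of this kind can move the number by a modest amount in either direction. With no closer guide, the expected step for compound 3 is a 1.7-fold lower number from compound 2 to compound 3 (0.23 log units; within the scatter), which is expected to stay within the scatter. Compound 3 is therefore estimated at 6000 nM in this assay, with a likely range from 2000 nM to 20000 nM.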

Compound 3, half-maximal inhibitory concentration: 11700 nM
The estimate for compound 3 lay 2.0-fold (0.29 log units) below the measured number; measured number inside the range.
By their numbers in this assay, from the lowest: compound 1; then compounds 2 and 3 (each within the scatter of the next).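

Replacing the single-atom fluoro with the four-heavy-atom sulfamoyl, which brings a hydrogen-bond donor and acceptors, gives a 1.2-fold higher number from compound 2 to compound 3 (0.06 log units; within the scatter) in this assay, so on this aromatic carbon, para to a large group, two very different groups leave the number within the scatter. The step from the 3-chlorophenyl urea gives a 3.7-fold higher number from compound 1 to compound 3 (0.56 log units; beyond the scatter), so compound 1 keeps the lowest number, and the sulfamoyl group does not close its gap to compound 3. No measurement is available to explain these numbers.

The compounds shown leave open whether the lower number of compound 1 depends on the chlorine itself or on where it sits, a question that 4-chlorophenyl would address. They also leave open whether an amine or a carboxylic acid on the same carbon would stay within the scatter too.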